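A few compounds are considered here, and "the series" means these few. Any claim that something is new, unique, unknown or untested is made for them only; others in the source may bear on it.

Measured compounds:
compound 1 `C/N=C(/S)C1=CC(C(F)(F)F)(C(F)(F)F)Oc2ccc([N+](=O)[O-])cc21`: 68% in a functional assay on the whole organism (aorta) with Rattus norvegicus as the target; on this read-out lower numbers stand for smaller maximal responses and higher numbers for larger maximal responses
compound 2 `CNC(=O)C1=CC(C)(C)Oc2ccc([N+](=O)[O-])cc21`: 61%
compound 3 `CNC(=O)C1=CC(C)(C(F)(F)F)Oc2ccc([N+](=O)[O-])cc21`: 61.7%

Compound 3 stands second highest of the three numbers. Compound 2 lies nearest, and the step of a number 0.7 percentage points higher from compound 2 to compound 3 (within the scatter) is within the scatter. Compound 1 lies furthest, yet its value and that of compound 3 also sit within the scatter of each other, so no order can be read among the three.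

Compound 4 `CNC(=O)C1=CC(C(F)(F)F)(C(F)(F)F)Oc2ccc([N+](=O)[O-])cc21` differs from compound 3 by trifluoromethyl in place of methyl on a saturated ring carbon. Going by the values given here, the one measured step that bears on this change is a number 0.7 percentage points higher from compound 2 to compound 3 (within the scatter), the same replacement on the same kind of saturated ring carbon, and it did not exceed the scatter. In this assay compound 4 is therefore expected to show no step beyond the scatter, the estimated change being a number 1.3 percentage points higher from compound 3 to compound 4 (within the scatter). The estimate for compound 4 is 63%, within 52% to 74%.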

Compound 4, intrinsic activity: the largest response reached, in percent of the reference agonist's: 57.9%
Compound 4: the middle estimate sits 5.1 percentage points above what was measured; the measured number falls inside the stated range.
By their numbers in this assay, from the lowest: compounds 4, 2, 3 and 1 (each within the scatter of the next, the first and the last beyond it).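

With both neighbouring steps at this saturated ring carbon now read, the second replacement of methyl by trifluoromethyl, a number 3.8 percentage points lower from compound 3 to compound 4 (within the scatter) in this assay, also stays inside the scatter, so neither replacement shows a measurable effect on the maximal response. Going by these compounds alone, the first step beyond the scatter lies elsewhere, at the double-bonded ring carbon, where the oxygen-bearing group replaces the sulfur-bearing group: a number 10.1 percentage points lower from compound 1 to compound 4 (beyond the scatter). No available evidence bears on the origin of either step.

Open, going by these compounds, is whether ethyl at the saturated ring carbon, or a carboxylic acid or an amine in place of the methylcarbamoyl group, would shift the maximal response.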